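Aryl variation on the shared core: estimate for compound 4

The compounds below may be only part of what the source reports. "The series", "measured", "known", "first", "only" and "open" are said of these compounds alone.

compound 1 `O=[N+]([O-])c1ccc(CN2CCC(n3cc(CC(OCc4cc(-c5ccccc5)no4)c4ccc(Br)cc4)nn3)CC2)cc1`: in a functional assay on MDA-MB-231 cells (Homo sapiens) for cytotoxicity, with a stated time of 48 h (on this read-out lower numbers stand for stronger inhibition and higher numbers for weaker inhibition), compound 1 gives > 25000 nM, a limit of the assay.
compound 2 `O=[N+]([O-])c1ccc(CN2CCC(n3cc(CC(OCc4cc(-c5ccc(F)cc5)no4)c4ccc(Br)cc4)nn3)CC2)cc1`: in this assay compound 2 gives > 25000 nM, likewise a limit.
compound 3 `O=[N+]([O-])c1ccc(CN2CCC(n3cc(CC(OCc4cc(-c5cccc(F)c5)no4)c4ccc(Br)cc4)nn3)CC2)cc1`: in this assay compound 3 gives 5000 nM.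

Within the data shown here, compound 3 holds the only readable number in the set; the other two entries sit at the assay limit (the limit of > 25000 nM in this assay, at which 2 of the 3 values shown sit). Both measured steps run toward compound 3: an at least 5.0-fold lower number from compound 1 to compound 3 (0.69 log units; beyond the scatter) and an at least 5.0-fold lower number from compound 2 to compound 3 (0.69 log units; beyond the scatter), each beyond the scatter, while the step that the two limits leave unreadable from compound 1 to compound 2 cannot be read between the two limits. Compound 4 `O=[N+]([O-])c1ccc(CN2CCC(n3cc(CC(OCc4cc(-c5ccccc5Br)no4)c4ccc(Br)cc4)nn3)CC2)cc1` differs from compound 3 by 2-bromophenyl in place of 3-fluorophenyl on an aromatic carbon. Among the measured compounds shown here, no measured step exchanges fluorine for bromine, and none places a substituent where the bromine of compound 4 sits; the two readable steps show only that the 3-fluorophenyl of compound 3 gives the one number, whereas the unsubstituted phenyl of compound 1 and the 4-fluorophenyl of compound 2 stay at the limit. Losing the 3-fluorophenyl is therefore expected to weaken the read-out. Compound 4 is estimated at 12000 nM, with a range of 3000 nM to 25000 nM, an expected step of a 2.4-fold higher number from compound 3 to compound 4 (0.38 log units; beyond the scatter).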

Compound 4, half-maximal inhibitory concentration: > 25000 nM
Compound 4: only a limit was reported (the forecaster's own chance of this, stated with the estimate: 45%); at least 2.0-fold (0.31 log units) between middle value and limit.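

In this assay, 2-bromophenyl in place of 3-fluorophenyl on this aromatic carbon of the five-membered ring gives an at least 5.0-fold higher number from compound 3 to compound 4 (0.69 log units; beyond the scatter), so a halogen on the phenyl group is not enough to keep a readable number at this position. Among these compounds, compound 3 remains the only compound with a number, and the new result adds a third aryl group at the assay limit: the limit of > 25000 nM in this assay, at which 3 of the 4 values shown sit. The steps among compound 1, compound 2 and compound 4 join limit to limit and cannot be read.

Compound 4 differs from compound 3 in both the halogen and its place on the phenyl group, and the compounds shown do not separate these two changes. Still open, on these data alone, is how 3-bromophenyl, 2-fluorophenyl or 3-chlorophenyl would read at this position.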